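The source may hold more compounds than are shown below. What is called first, only, known or untested is meant among the compounds shown, and "the series" means these compounds.

Working notes on the series.

Compound 1 `Fc1ccc(-c2nn(-c3ccccc3)cc2-c2nc3cc(Cl)ccc3[nH]2)cc1` is the reference. In a functional assay on MCF7 cells (Homo sapiens) for antiproliferative activity, read by MTT assay, with a stated time of 48 h (a higher number here means a weaker inhibitor, a lower number a stronger inhibitor), compound 1 gives 2230 nM. Compound 2 `COc1ccc2[nH]c(-c3cn(-c4ccccc4)nc3-c3ccc(F)cc3)nc2c1` carries methoxy in place of chloro on an aromatic carbon and in this assay compound 2 gives 970 nM; the resulting step of a 2.3-fold lower number from compound 1 to compound 2 (0.36 log units; beyond the scatter) is modest but beyond the scatter. Compound 3 `Fc1ccc2[nH]c(-c3cn(-c4ccccc4)nc3-c3ccc(Cl)cc3)nc2c1` has the same atoms as compound 1, joined differently; the difference between the two cores is not broken down here. In this assay compound 3 gives 2830 nM, which is within the scatter of compound 1 and sits beyond the scatter of compound 2.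

Compound 4 `COc1ccc(-c2nn(-c3ccccc3)cc2-c2nc3cc(F)ccc3[nH]2)cc1` has not yet been measured. It differs from compound 3 by methoxy in place of chloro on an aromatic carbon. Within the data shown here, this is the same kind of change as the one from compound 1 to compound 2, but not the same: in the measured pair the replaced group sits on a ring that is part of a fused or bridged system of two rings, meta to a fused ring and para to a fused ring, whereas in compound 4 it sits on a six-membered aromatic ring of carbon only, para to a large group. Because a 2.3-fold lower number from compound 1 to compound 2 (0.36 log units; beyond the scatter) was modest, a step of similar direction and size is expected from compound 3 to compound 4, but with wider uncertainty since the surroundings of the place differ. The estimated step is a 1.9-fold lower number from compound 3 to compound 4 (0.28 log units; within the scatter). For compound 4 the expected value in this assay is 1500 nM, estimated to lie between 700 nM and 3300 nM.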

Compound 4, half-maximal inhibitory concentration: 1510 nM
For compound 4 the middle estimate is 1.0-fold (0.00 log units) below the measured one; the measured number falls inside the stated range.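

In this assay, methoxy in place of chloro at the 4-chlorophenyl position gives a 1.9-fold lower number from compound 3 to compound 4 (0.27 log units; within the scatter), so this step taken alone does not establish a change in the number. Its direction matches that of the earlier step, made at a different place on the shared core, and the two steps do not differ in size: the comparison reads (the same change on two cores in this assay, a 2.3-fold lower number (0.36 log units; beyond the scatter) from compound 1 to compound 2 and a 1.9-fold lower number (0.27 log units; within the scatter) from compound 3 to compound 4, 1.2-fold (0.09 log units) apart, within the scatter of two such steps). This supports treating the change as similar in direction and size across these two pairs, but it rests on two steps only, one of them within the scatter, and shows neither a rule for other cores nor why the numbers move as they do.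

From the compounds shown here alone, what an amine or a carboxylic acid in place of chloro, or a chain longer than methoxy, would do at either place remains open. Also open is whether the two replacements would add up if both were present on a single compound, since each pair shown carries the change at one place only.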